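The source may hold more compounds than are shown below. What is called first, only, known or untested is meant among the compounds shown, and "the series" means these compounds.

Measured in a functional assay for inhibition, with Rattus norvegicus as the target; a lower number here means a stronger inhibitor, a higher number a weaker inhibitor:
- compound 1 `CCc1c(CC)c(OC)c2c(OC)cccc2c1OC(C)=O`: 890 nM
- compound 2 `CCc1c(CC)c(OC(C)=O)c2c(C)c(C)cc(C)c2c1OC`: 15700 nM
- compound 3 `CCc1c(CC)c(OC)c2c(C)cccc2c1OC(C)=O`: 830 nM

Compound 3 gives 830 nM and stands level with compound 1 within the scatter, well under compound 2 at 15700 nM on this scale. Compound 4 `CCc1c(CC)c(OC(C)=O)c2c(C)ccc(C)c2c1OC` follows from compound 3 by methyl in place of hydrogen on an aromatic carbon. Among the compounds with values here, the one measured step, a 1.1-fold lower number from compound 1 to compound 3 (0.03 log units; within the scatter), swapped methoxy for methyl, so it says little about adding a methyl. Only compound 2, which carries more methyl groups, at 15700 nM hints at a weaker inhibitor, and that evidence is thin. A moderate rise is therefore expected, a 3.0-fold higher number from compound 3 to compound 4 (0.48 log units; beyond the scatter) in this assay as estimated here. For compound 4 the estimated value is 2500 nM, with a likely range of 800 nM to 9000 nM.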

Compound 4, half-maximal inhibitory concentration: 13000 nM
Estimate against measurement, compound 4: 5.2-fold (0.72 log units) below; the whole stated range lies below it.
By their numbers in this assay, from the lowest: compounds 3 and 1 (each within the scatter of the next); then compounds 4 and 2 (each within the scatter of the next).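

In this assay the single methyl on this aromatic carbon, para to a methyl group, brings a large weakening (a 16-fold higher number from compound 3 to compound 4 (1.19 log units; beyond the scatter)). That is something the swap of methoxy for methyl could not show. The other methyl position behaves differently, since hydrogen in place of methyl there makes no difference beyond the scatter (a 1.2-fold lower number from compound 2 to compound 4 (0.08 log units; within the scatter)), so a further methyl adds nothing once this one is present. Nothing available explains the weakening.

From the compounds shown here alone, whether chlorine or an amine at this carbon would weaken inhibition as strongly as methyl stays open.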